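A few compounds are considered here, and "the series" means these few. Any claim that something is new, unique, unknown or untested is made for them only; others in the source may bear on it.

In a functional assay on HCT-116 cells (Homo sapiens) for inhibition, read by CCK-8 assay, with a stated time of 48 h (on this read-out higher numbers stand for weaker inhibition and lower numbers for stronger inhibition), compound 3 `CCN1CCN(CC(=O)N(Cc2ccc(OC)cc2)c2cc(OC)c(OC)c(OC)c2)CC1` gives > 20000 nM, which is a limit of the assay and not a number. Compound 1 `COc1ccc(CN(C(=O)CSc2nc3ccccc3o2)c2cc(OC)c(OC)c(OC)c2)cc1` gives 3280 nM, and compound 2 `COc1ccc(CN(C(=O)CSC(=S)N2CCN(C(C)=O)CC2)c2cc(OC)c(OC)c(OC)c2)cc1` gives 1370 nM. Compound 4 `COc1ccc(CN(C(=O)CN2CCN(C(C)=O)CC2)c2cc(OC)c(OC)c(OC)c2)cc1` differs from compound 3 by having acetyl in place of ethyl on an amine nitrogen in a ring. Among the measured compounds shown here, no measured pair makes this change alone. The closest guides are the large at least 14-fold higher number from compound 2 to compound 3 (1.16 log units; beyond the scatter) and the smaller at least 6.0-fold higher number from compound 1 to compound 3 (0.78 log units; beyond the scatter), and both replace much more than this one group. Only a small part of such a gap is therefore expected here, and the result may again be a limit. The expected change is an at least 1.6-fold lower number from compound 3 to compound 4 (0.22 log units; that floor lies within the scatter). Compound 4 is estimated at 12000 nM, with an expected range of 4000 nM to 30000 nM.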

Compound 4, half-maximal inhibitory concentration: > 20000 nM
Compound 4 ended at the assay's limit (the forecaster's own chance of this, stated with the estimate: 45%); at least 1.6-fold (0.22 log units) between middle value and limit.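

Acetyl in place of ethyl on an amine nitrogen in a ring does not bring the compound into the readable range, so the step from compound 3 to compound 4 cannot be read; both stand at a limit of the assay, not at a number: the limit of > 20000 nM in this assay, at which 2 of the 4 values shown sit.

With acetyl, as with ethyl, the piperazine compound stays far from the compounds that carry sulfur on the chain carbon, with an at least 14-fold higher number from compound 2 to compound 4 (1.16 log units; beyond the scatter) and an at least 6.0-fold higher number from compound 1 to compound 4 (0.78 log units; beyond the scatter).

Going by these compounds, how far compound 3 and compound 4 lie beyond the limit stays open. So does whether a benzoyl group or a longer chain in place of acetyl would give a readable value.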